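This account rests on a few compounds, and the source may have more. Where it says the series, first, only, none or still open, it means among the compounds named here.

Measured in a functional assay on HT-29 cells (Homo sapiens) for cytotoxicity, read by sulforhodamine B assay, with a stated time of 72 h; on this read-out lower numbers stand for stronger inhibition of growth and higher numbers for weaker inhibition of growth:
- compound 1 `C=C1CC[C@@H]2[C@](C)(CCC[C@]2(C)C(=O)OC)[C@H]1CCc1ccc2c(c1)C(=O)C=CC2=O`: 200 nM
- compound 2 `C=C1CC[C@@H]2[C@](C)(CCC[C@]2(C)C(=O)OC)[C@H]1CCc1ccc2c(OCc3ccccc3)ccc(OCc3ccccc3)c2c1`: > 5000 nM (a limit)
- compound 3 `C=C1CC[C@@H]2[C@](C)(CCC[C@]2(C)C(=O)OCc2ccccc2)[C@H]1CCc1ccc2c(OCc3ccccc3)ccc(OCc3ccccc3)c2c1`: 4400 nM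

The starting point of this step has no exact number. For compound 2, the reading of > 5000 nM is a limit of the assay and not a number. Compound 4 `C=C1[C@H](O)C[C@@H]2[C@](C)(CCC[C@]2(C)C(=O)OC)[C@H]1CCc1ccc2c(OCc3ccccc3)ccc(OCc3ccccc3)c2c1` carries hydroxy in place of hydrogen on a saturated ring carbon.

For the measured compounds named here, only one measured step links two compounds that differ in one place, and it lies elsewhere in the molecule: an at least 1.1-fold lower number from compound 2 to compound 3 (0.05 log units; that floor lies within the scatter). Going by the values given here, it says nothing directly about adding a hydroxy, and no measured compound tests that change. Compound 1 gives a much lower number, 200 nM, but it differs from compound 2 in more than one place, so it cannot size this step.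

With no measured guide, no step beyond the scatter is expected in this assay, and no direction can be favoured. Compound 4 should therefore stay in the weak region set by compound 3 at 4400 nM. Compound 4 may well give only a limit too. The expected change is a number no higher from compound 2 to compound 4 (the limit leaves the size open). For compound 4 the estimated value is 5000 nM, with an expected range from 2000 nM to 10000 nM.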

Compound 4, concentration for 50% growth inhibition: > 4900 nM
Compound 4 ended at the assay's limit (the forecaster's own chance of this, stated with the estimate: 55%); the middle value does not contradict the limit.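

In this assay compound 4 gives only a limit and not a number: the limit of > 4900 nM in this assay, at which 1 of the 4 values shown sits.

Compound 2 also gives only a limit: the limit of > 5000 nM in this assay, at which 1 of the 4 values shown sits.

So no step can be read between compound 2 and compound 4. The compounds shown leave open whether hydroxy in place of hydrogen on this saturated ring carbon changes growth inhibition at all, and in which direction.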